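From a cyclopentyl amide toward a benzyl carbamate

The compounds below may be only part of what the source reports. "The series", "measured", "known", "first", "only" and "open" are said of these compounds alone.

Compound 1, `Cc1cc(C(=O)NCc2ccccc2)nn1Cc1cc(Cl)ccc1OCc1ccccc1`: 39.8 nM
Compound 2, `Cc1cc(NC(=O)C(C)C)nn1Cc1cc(Cl)ccc1OCc1ccccc1`: 25.1 nM
Compound 3, `Cc1cc(NC(=O)C2CCCC2)nn1Cc1cc(Cl)ccc1OCc1ccccc1`: 15.9 nM

All three were tested in an assay on CHO-K1 cells for displacement of a labelled ligand from prostaglandin E2 receptor EP1 subtype (Homo sapiens); a lower number here means a stronger inhibitor, a higher number a weaker inhibitor. Compound 3 gives the lowest number of the three. Its separation from compound 1 is real, since a 2.5-fold lower number from compound 1 to compound 3 (0.40 log units; beyond the scatter) lies beyond the scatter, whereas a 1.6-fold lower number from compound 2 to compound 3 (0.20 log units; within the scatter) lies within it, so compound 3 and compound 2 cannot be told apart on these numbers. The remaining step, a 1.6-fold lower number from compound 1 to compound 2 (0.20 log units; within the scatter), is also within the scatter.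

Compound 4, `Cc1cc(NC(=O)OCc2ccccc2)nn1Cc1cc(Cl)ccc1OCc1ccccc1`, has not been measured. Its change from compound 3 is benzyloxy in place of cyclopentyl on a carbonyl carbon. Going by the values given here, two measured steps bear on it. The exchange at the carbonyl carbon, a 1.6-fold lower number from compound 2 to compound 3 (0.20 log units; within the scatter), was within the scatter, which suggests that this position tolerates a change of substituent. Among the compounds with values here, the only compound carrying a benzyl group on the amide side chain, compound 1, gave the highest number, though the carbamate of compound 4 is not the same arrangement. Taken together, one expects at most a small step toward a higher number, a 1.6-fold higher number from compound 3 to compound 4 (0.20 log units; within the scatter), possibly none beyond the scatter. Compound 4 is therefore estimated at 25 nM, with a range from 10 nM to 63 nM.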

Compound 4, half-maximal inhibitory concentration: 79.4 nM
Estimate against measurement, compound 4: 3.2-fold (0.50 log units) below; the measured number lies above the stated range.
By their numbers in this assay, from the lowest: compounds 3, 2, 1 and 4 (each within the scatter of the next, the first and the last beyond it).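

In this assay, the carbonyl carbon whose other neighbour is the amide-type nitrogen proves less tolerant than the exchange of isopropyl for cyclopentyl alone suggested, since benzyloxy separates clearly from both earlier groups (a 5.0-fold higher number from compound 3 to compound 4 (0.70 log units; beyond the scatter)) and (a 3.2-fold higher number from compound 2 to compound 4 (0.50 log units; beyond the scatter)). Compound 4 cannot be told apart from compound 1 (a 2.0-fold higher number from compound 1 to compound 4 (0.30 log units; within the scatter)), yet this does not make a simple rule for groups ending in benzyl, as compound 1 also cannot be told apart from compound 2, whereas compound 4 stands beyond the scatter from it. Nothing in the data accounts for the step from cyclopentyl to benzyloxy.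

The change brings in both an oxygen and a phenyl ring, and these compounds do not separate the two: a cyclopentyloxy group on the same carbonyl carbon would test the oxygen with the ring of compound 3 kept, and a benzyl or 2-phenylethyl group there would test the phenyl ring without the oxygen. From the compounds shown here alone, a benzylamino group at that carbon, giving a urea, also remains open as a comparison with the carbamate of compound 4.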